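The compounds below may be only part of what the source reports. "The series", "measured", "known", "first", "only" and "open" are said of these compounds alone.

Working notes on the series. In a functional assay on HEL cells (Homo sapiens) (a lower number here means that less compound is tolerated, a higher number that more compound is tolerated), compound 2 `Cc1cn([C@@H]2O[C@H](CO[Si](C)(C)C(C)(C)C)[C@@]3(OS(=O)(=O)C=C3NC(=O)NC(=O)c3ccccc3)[C@H]2O[Si](C)(C)C(C)(C)C)c(=O)n(C)c1=O` stands at >= 200000 nM, and this value is a limit of the assay, not a number. For the measured compounds named here, the only other measured compound is compound 1 `Cc1cn([C@@H]2O[C@H](CO[Si](C)(C)C(C)(C)C)[C@@]3(OS(=O)(=O)C=C3NC(N)=O)[C@H]2O[Si](C)(C)C(C)(C)C)c(=O)n(C)c1=O`, at 11000 nM. Going by the values given here, the one measured step that bears on the change is an at least 18-fold higher number from compound 1 to compound 2 (1.25 log units; beyond the scatter), with benzoyl in place of hydrogen on an amide-type nitrogen. The size of that step is tied to the limit of >= 200000 nM in this assay, at which 1 of the 2 values shown sits. Compound 3 `CCNC(=O)NC1=CS(=O)(=O)O[C@@]12[C@@H](CO[Si](C)(C)C(C)(C)C)O[C@@H](n1cc(C)c(=O)n(C)c1=O)[C@@H]2O[Si](C)(C)C(C)(C)C` is not yet measured and carries ethyl in place of benzoyl on an amide-type nitrogen. Among the compounds with values here, this change removes the same benzoyl, but ethyl rather than hydrogen takes its place, and no measured step covers ethyl. A large move to a lower number in this assay is expected, resting on compound 1 at 11000 nM, though it may stop short of that level. The step expected is an at least 5.0-fold lower number from compound 2 to compound 3 (0.69 log units; beyond the scatter). Compound 3 is estimated at 40000 nM, with an expected range of 12000 nM to 150000 nM.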

Compound 3, half-maximal cytotoxic concentration: 10000 nM
Compound 3: middle estimate off by 4.0-fold (0.60 log units), on the high side; measured number outside the range, below it.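

In this assay, ethyl and hydrogen on the amide-type nitrogen cannot be told apart, with a 1.1-fold lower number from compound 1 to compound 3 (0.04 log units; within the scatter), so the replacement of hydrogen by ethyl alone leaves the read-out within the scatter. Among the three compounds, only the benzoyl-bearing compound 2 stands apart, with an at least 20-fold lower number from compound 2 to compound 3 (1.30 log units; beyond the scatter), so the higher tolerated concentration goes with benzoyl and not with just any substituent on this nitrogen. The size of that step has no fixed upper end, and the value for compound 2 is a limit of the assay and not a number: the limit of >= 200000 nM in this assay, at which 1 of the 3 values shown sits.

On these data alone, it remains open whether the separation follows the whole benzoyl group, its six-membered aromatic ring or its carbonyl, which an acetyl or a benzyl group on the same nitrogen would help to distinguish. As far as these compounds go, it also remains open whether a longer chain such as butyl, or a chain ending in an amine, would stay level with ethyl and hydrogen or move towards compound 2.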